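A few compounds are considered here, and "the series" means these few. Any claim that something is new, unique, unknown or untested is made for them only; others in the source may bear on it.

Working notes on the series in an assay on membranes from brain for displacement of a labelled ligand from Neuronal acetylcholine receptor; alpha4/beta2 (Rattus norvegicus); a higher number here means a weaker inhibitor, a lower number a stronger inhibitor.

Compound 1 `Cc1ncccc1OC[C@@H]1CCCN1C` gives 22.9 nM. Within the data shown here, compound 2 `CN1CCC[C@H]1COc1cccnc1[N+](=O)[O-]` gives 9000 nM; the only one-place step recorded so far is a 390-fold higher number from compound 1 to compound 2 (2.59 log units; beyond the scatter), and it concerns a different position and a different pair of groups from the change considered here. Compound 3 `CN1CCC[C@H]1COc1cncc(C(F)(F)F)c1` gives 1.83 nM, the lowest of the three numbers: compound 1 stands nearest to it and compound 2 furthest from it, and both of those gaps lie beyond the scatter.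

Compound 4 `CCc1cncc(OC[C@@H]2CCCN2C)c1` is not yet measured. It differs from compound 3 by ethyl in place of trifluoromethyl on an aromatic carbon. Among the measured compounds shown here, no recorded step concerns an exchange of trifluoromethyl for ethyl, so the step from compound 1 to compound 2 bears on it only as a reminder that a single change on the ring can move this assay a long way. For the measured compounds named here, with no direct precedent, the expectation for compound 4 is a small step toward a higher number, a 2.7-fold higher number from compound 3 to compound 4 (0.44 log units; beyond the scatter), giving an estimated 5 nM with a range from 1.5 nM to 20 nM.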

Compound 4, inhibition constant: 0.32 nM
The estimate for compound 4 lay 16-fold (1.19 log units) above the measured number; the whole stated range lies above it.
By their numbers in this assay, from the lowest: compound 4; then compound 3; then compound 1; then compound 2.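

In this assay, the exchange of trifluoromethyl for ethyl, two atoms from the ring nitrogen, gives a 5.7-fold lower number from compound 3 to compound 4 (0.76 log units; beyond the scatter) and so lies beyond the scatter. Among these compounds, at this place on the ring, trifluoromethyl with its 4 heavy atoms is therefore not required for a low number, and ethyl with 2 heavy atoms, both groups having no hydrogen-bond donors or acceptors, goes further down; the only earlier one-place step concerned a different position and ran toward a higher number. No available measurement accounts for this step.

A single pair cannot separate the loss of fluorine from the change in group size at this position. It also leaves open how methyl, propyl or a longer chain would read here, and whether a nitrile or an amine would be accepted at the same place.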